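This account rests on a few compounds, and the source may have more. Where it says the series, first, only, none or still open, it means among the compounds named here.

Compound 2 `Cc1ccc(Nc2nc(Cl)nc3c2ncn3Cc2ccc(C(=O)Nc3ccccc3N)cc2)cc1` stands highest of the three measured compounds in a functional assay on HepG2 cells (Homo sapiens) for antiproliferative activity, read by CCK-8 assay, with a stated time of 72 h, tested at 8 uM (a lower number here means a weaker effect, a higher number a stronger effect of the compound at the concentration tested), where compound 2 gives 82%. Compound 3 `Cc1ccc(Nc2nc(Cl)nc3c2ncn3Cc2ccc(/C=C/C(=O)Nc3ccccc3N)cc2)cc1` carries the same core, and in this assay compound 3 gives 43%. Compound 1 `CC(C)n1cnc2c(Nc3ccccc3)nc(NCOCc3ccc(/C=C/C(=O)Nc4ccccc4N)cc3)nc21` differs from both in more than one place, and in this assay compound 1 gives 40.8%. Among the measured compounds shown here, the only step between compounds that differ in a single place is a number 39 percentage points lower from compound 2 to compound 3 (beyond the scatter), and it concerns the link to the (2-aminophenyl)carbamoyl group, not the part of the shared core that changes here.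

Compound 4 `CC1CCN(c2nc(Cl)nc3c2ncn3Cc2ccc(C(=O)Nc3ccccc3N)cc2)CC1` differs from compound 2 in one place: 4-methylpiperidin-1-yl in place of (4-methylphenyl)amino on an aromatic carbon. For the measured compounds named here, no measured pair shows an exchange of this kind, so there is no step in this assay to set beside it; the one known step shows only that a single change can move the read-out a long way. The one hydrogen-bond donor of the leaving group is lost while the rest of the molecule stays as in compound 2. A weaker effect than that of compound 2 is expected for compound 4, a step of a number 27 percentage points lower from compound 2 to compound 4 (beyond the scatter), with wide uncertainty. The estimate for compound 4 in this assay is 55%, within a range from 25% to 85%.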

Compound 4, a percentage reported as inhibition, at one concentration (the size of the read-out at that concentration, not a potency): 65.3%
Beside the measured number, compound 4's estimate is 10.3 percentage points below it, and the stated range covers the measured number.
By their numbers in this assay, from the lowest: compounds 1 and 3 (each within the scatter of the next); then compound 4; then compound 2.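

Among the compounds shown here, this is the first look at the aromatic carbon next to the ring nitrogen, and in this assay the exchange of (4-methylphenyl)amino for 4-methylpiperidin-1-yl gives a number 16.7 percentage points lower from compound 2 to compound 4 (beyond the scatter). The position therefore responds to the change, yet compound 4, with a non-aromatic ring and no hydrogen-bond donor in this group, still gives 65.3%, so neither the aromatic ring nor the donor is needed for a clear effect at this concentration. No measurement at hand accounts for the loss seen with this exchange.

The exchange removes the aromatic ring and the hydrogen-bond donor together, so the compounds shown cannot tell how much of the step belongs to each; a cyclohexylamino group, which keeps an amino hydrogen on a non-aromatic ring, could begin to separate the two. Also open, on these data alone, is whether the same exchange would give a step of similar size with the 2-((2-aminophenyl)carbamoyl)ethenyl group, and whether a read-out at one concentration would follow the same order as full potency measurements.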